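A few compounds are considered here, and "the series" means these few. Any claim that something is new, unique, unknown or untested is made for them only; others in the source may bear on it.

Measured in an ADME assay on Vero cells (Chlorocebus sabaeus) for cytotoxicity, read by CellTiter-Glo and ATP content, with a stated time of 72 h; a lower number here means that less compound is tolerated, a higher number that more compound is tolerated:
Compound 1 `Nc1c(C2=NCCCN2)cnn1-c1ccc(Cl)cc1`: > 500000 nM (a limit)
Compound 2 `Nc1c(C2=NCCCN2)cnn1-c1ccc(F)cc1`: > 500000 nM (a limit)

Compound 2 gives > 500000 nM in this assay, which is a limit of the assay and not a number. For the measured compounds named here, the one further value shown, that of compound 1, is also a limit. Both readings therefore come down to the limit of > 500000 nM in this assay, at which 2 of the 2 values shown sit.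

The next compound is compound 3 `Nc1c(C2=NCCCN2)cnn1-c1ccc(Br)cc1`, and the change is bromo in place of fluoro on an aromatic carbon. Going by the values given here, the one measured step that bears on this change is a step that the two limits leave unreadable from compound 1 to compound 2, which also exchanges the group at this place. Its size cannot be read, so it offers no size or direction to carry over. No step beyond the usual scatter is expected in this assay, and compound 3 may well be reported as a limit too. The estimated step is a number no higher from compound 2 to compound 3 (the limit leaves the size open). For compound 3 the expected value is 500000 nM, with an expected range from 250000 nM to 1000000 nM.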

Compound 3, half-maximal cytotoxic concentration: > 500000 nM
Compound 3: a limit, no number; the forecaster's own chance of this, stated with the estimate: 85%; the middle value lies on the limit itself.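

Compound 3 gives > 500000 nM in this assay, a limit and not a number. No step among compound 1, compound 2 and compound 3 can be read: the limit of > 500000 nM in this assay, at which 3 of the 3 values shown sit.

The compounds shown leave open whether the chloro, fluoro and bromo compounds differ at all in the concentration tolerated, and in which direction.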